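The source may report more compounds than this note shows. Statements on the series, on what has been measured and on what is new or still open speak of the compounds shown alone.

Compound 1, `Cc1nsc2c1ncn2[C@H]1C[C@H](O)[C@@H](CO)O1`, in a functional assay on L1210 cells (Mus musculus) for antiproliferative activity (on this read-out higher numbers stand for weaker inhibition and lower numbers for stronger inhibition), gives > 100000 nM, which is a limit of the assay and not a number.
Compound 2, `CSc1nc2cnsc2n1[C@H]1C[C@H](O)[C@@H](CO)O1`, in this assay gives > 100000 nM, again a limit of the assay rather than a number.
Compound 3, `Cc1nsc2ncn([C@H]3C[C@H](O)[C@@H](CO)O3)c12`, in this assay gives 78000 nM.

Among these three, compound 3 is the only one for which a number was obtained at all; the other two sit at the limit of > 100000 nM in this assay, at which 2 of the 3 values shown sit, so nothing can be said about how far apart they are, only that compound 3 was strong enough to be read. Even so, the number for compound 3 is a very weak one.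

Compound 4, `CSc1nc2snc(C)c2n1[C@H]1C[C@H](O)[C@@H](CO)O1`, has not yet been measured. It is built from compound 3 by a single change: methylsulfanyl in place of hydrogen on an aromatic carbon. Compound 2 carries the same methylsulfanyl group on a differently arranged core, and it reached only the limit of the assay, which gives no ground to expect a gain from this group here.

Compound 4 is therefore expected to stay at the weak end, with a step of a 1.2-fold higher number from compound 3 to compound 4 (0.06 log units; within the scatter) that does not go beyond the usual scatter. The estimate for compound 4 is 90000 nM, within a range from 30000 nM to 300000 nM, with a real chance that the assay again reports only a limit.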

Compound 4, half-maximal inhibitory concentration: 33000 nM
Compound 4: the middle estimate sits 2.7-fold (0.44 log units) above what was measured; low and high end bracket the measured number.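

Putting methylsulfanyl in place of hydrogen on this aromatic carbon, between two ring nitrogen atoms, gives a 2.4-fold lower number from compound 3 to compound 4 (0.37 log units; beyond the scatter) in this assay, a move towards stronger inhibition. This is the first change among these compounds whose size can be read as a step, and it shows that this position accepts a group larger than hydrogen without a loss of activity on this read-out. The gain is real but small in practical terms, since both compound 3 and compound 4 remain very weak inhibitors of cell growth.

On these data alone, what stays open is whether the gain belongs to methylsulfanyl in particular or would come with other groups on the same carbon, such as an amine, a chlorine atom or a longer chain like ethylsulfanyl, and one change at one position cannot settle that. Whether the same change would help on the differently arranged cores also remains unknown, as the values there give no number to build a step on: the limit of > 100000 nM in this assay, at which 2 of the 4 values shown sit.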